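This account rests on a few compounds, and the source may have more. Where it says the series, first, only, none or still open, it means among the compounds named here.

Measured in a functional assay on K562 cells (Homo sapiens) for antiproliferative activity, with a stated time of 72 h; a lower number here means a stronger inhibitor, a higher number a weaker inhibitor:
- compound 1 `Nc1ncnn2c([C@@H]3O[C@H](CO)[C@@H](O)[C@H]3O)cc(C#CC3CC3)c12` gives 40 nM
- compound 2 `Nc1ncnn2c([C@@H]3O[C@H](CO)[C@@H](O)[C@H]3O)cc(C#Cc3cccs3)c12` gives > 100000 nM, which is a limit of the assay
- compound 3 `Nc1ncnn2c([C@@H]3O[C@H](CO)[C@@H](O)[C@H]3O)cc(-c3ccc(F)cc3F)c12` gives 69700 nM

Compound 3 holds the higher of the two exact numbers. The large steps are a 1700-fold higher number from compound 1 to compound 3 (3.24 log units; beyond the scatter) and an at least 2500-fold higher number from compound 1 to compound 2 (3.39 log units; beyond the scatter), whereas the exchange of one aromatic group for another gave an at least 1.4-fold lower number from compound 2 to compound 3 (0.15 log units; that floor lies within the scatter).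

Compound 4 `Nc1ncnn2c([C@@H]3O[C@H](CO)[C@@H](O)[C@H]3O)cc(/C=C/c3ccccc3)c12` carries 2-phenylethenyl in place of 2,4-difluorophenyl on an aromatic carbon. This is again an exchange between groups bearing an aromatic ring, so the last step is the closest guide and no step beyond the scatter is expected in this assay. The estimated step is a 1.7-fold lower number from compound 3 to compound 4 (0.24 log units; within the scatter). For compound 4 the expected value is 40000 nM, with an estimated range of 4000 nM to 100000 nM.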

Compound 4, half-maximal inhibitory concentration: 3100 nM
Beside the measured number, compound 4's estimate is 13-fold (1.11 log units) above it, and the stated range ends above it.
By their numbers in this assay, from the lowest: compound 1; then compound 4; then compound 3. At a limit, above all of these: compound 2.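

Sharing a six-membered aromatic ring does not make two groups equivalent at this position in this assay: there is a 22-fold lower number from compound 3 to compound 4 (1.35 log units; beyond the scatter) (2-phenylethenyl against 2,4-difluorophenyl). Compound 2 stands at a limit of the assay, so an at least 32-fold lower number from compound 2 to compound 4 (1.50 log units; beyond the scatter) is only a floor: the limit of > 100000 nM in this assay, at which 1 of the 4 values shown sits. Even so, there remains a 78-fold higher number from compound 1 to compound 4 (1.89 log units; beyond the scatter), leaving 2-cyclopropylethynyl clearly ahead.

Open, going by these compounds, is whether the double bond or the absent fluorines account for the change at compound 4; a plain phenyl group would separate the two. Also open, on these data alone, is whether an amine or a longer alkyl chain on the triple bond would hold the level of compound 1.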